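The source may report more compounds than this note shows. Statements on the series, on what has been measured and on what is new or still open speak of the compounds shown alone.

In an assay on isolated protein for inhibition of glutathione S-transferase Mu 2 (Homo sapiens), with a stated time of 10 min (a lower number here means a stronger inhibitor, a higher number a weaker inhibitor), compound 3 `O=C(CCC(=O)OCCCCCCSc1ccc([N+](=O)[O-])c2nonc12)Nc1ccc(Br)cc1` gives 32000 nM, the highest number among the three measured compounds; compound 1 `O=C(O)CCC(=O)OCCCCCCSc1ccc([N+](=O)[O-])c2nonc12` gives 160 nM and compound 2 `O=C(CCC(=O)OCCCCCCSc1ccc([N+](=O)[O-])c2nonc12)Nc1ccccc1F` gives 350 nM. Compound 4 `COc1ccc(NC(=O)CCC(=O)OCCCCCCSc2ccc([N+](=O)[O-])c3nonc23)cc1OC` differs from compound 3 only on the amide-type nitrogen: 3,4-dimethoxyphenyl in place of 4-bromophenyl on an amide-type nitrogen. Among the measured compounds shown here, the one measured step that swaps the aryl group on this nitrogen, a 91-fold higher number from compound 2 to compound 3 (1.96 log units; beyond the scatter), was large, and a 2.2-fold higher number from compound 1 to compound 2 (0.34 log units; beyond the scatter) next to a 200-fold higher number from compound 1 to compound 3 (2.30 log units; beyond the scatter) shows the same: which aryl group sits there can shift the number greatly. For the measured compounds named here, no measured compound carries a 3,4-dimethoxyphenyl, so the direction is uncertain. For compound 4 the expected step is a 6.4-fold lower number from compound 3 to compound 4 (0.81 log units; beyond the scatter), most likely a lower number, with a wide range. The estimate for compound 4 is 5000 nM, between 700 nM and 40000 nM.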

Compound 4, half-maximal inhibitory concentration: 360 nM
For compound 4 the middle estimate is 14-fold (1.14 log units) above the measured one, outside the stated range (below it).
By their numbers in this assay, from the lowest: compound 1; then compounds 2 and 4 (each within the scatter of the next); then compound 3.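

In this assay, the high number of the 4-bromophenyl amide does not hold for aryl amides in general: 3,4-dimethoxyphenyl on the same nitrogen gives an 89-fold lower number from compound 3 to compound 4 (1.95 log units; beyond the scatter). Two different aryl groups now sit level, with a 1.0-fold higher number from compound 2 to compound 4 (0.01 log units; within the scatter), and against the carboxylic acid the cost stays modest, with a 2.3-fold higher number from compound 1 to compound 4 (0.35 log units; beyond the scatter), leaving compound 3 as the one that goes against this pattern. Nothing shown here explains why the 4-bromophenyl stands apart. Open, on these data alone, is whether 4-chlorophenyl or 4-methoxyphenyl on this nitrogen would follow compound 3 or compound 4. Also open, as far as these compounds go, is how a benzyl group there would compare.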